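Serine amides: from methoxycarbonyl to cyclopropyl

The compounds below may be only part of what the source reports. "The series", "measured", "known", "first", "only" and "open" are said of these compounds alone.

Measured compounds:
Compound 1 `CC(C)(O)C(=O)N[C@@H](CO)C(=O)O` — "not determined" (no result reported)
Compound 2 `CN(C)C(=O)N[C@@H](CO)C(=O)O` — 30%
Compound 3 `COC(=O)C(=O)N[C@@H](CO)C(=O)O` — "not determined" (no result reported)

In an ADME assay on microsomes from liver (Mus musculus) for metabolic stability, with a stated time of 30 min (on this read-out higher numbers stand for a more stable compound and lower numbers for a less stable compound), compound 2 gives 30%. Compound 3 stands without a number in this assay; its result is "not determined" (no result reported), as is that of compound 1. Going by the values given here, the one measured value therefore comes from compound 2 alone, and nothing shows how compound 3 compares with it.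

Compound 4 `O=C(N[C@@H](CO)C(=O)O)C1CC1` differs from compound 3 in one place: cyclopropyl in place of methoxycarbonyl on a carbonyl carbon. Since compound 3 has no number in this assay, no size or direction of a step can be read from the data; the expectation for compound 4 rests only on the value of compound 2 and the change itself. Compound 4 is expected to give about 55% in this assay, within a range of 25% to 90%.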

Compound 4, percent of the compound remaining: 21%
Beside the measured number, compound 4's estimate is 34 percentage points above it; the measured number lies below the stated range.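

In this assay, two groups on a carbonyl carbon whose other neighbour is an amide-type nitrogen can now be compared, and cyclopropyl in place of dimethylamino gives a number 9 percentage points lower from compound 2 to compound 4 (within the scatter) on this read-out. The two groups therefore cannot be told apart here. Steps involving compound 1 or compound 3 cannot be read, and no supporting measurement accounts for the result.

As far as these compounds go, it remains open whether a longer carbon chain or a primary amine at this place would separate from these two compounds. From the compounds shown here alone, how methoxycarbonyl compares with either group also remains open.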